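Benzyl to Isopropyl on the Ether Oxygen of Compound 2

This account rests on a few compounds, and the source may have more. Where it says the series, first, only, none or still open, it means among the compounds named here.

Within the data shown here, compound 1 `Nc1cc(-c2ccc3cn[nH]c3c2)nc(N)n1` gives 660000 nM in a physicochemical assay for solubility, read by LC-MS, in phosphate buffer, measured as kinetic solubility, with a stated time of 24 h, at 25 degrees C, at pH 7.4 (a higher number here means a more soluble compound, a lower number a less soluble compound), while compound 3 `Nc1nccc(-c2ccc3cn[nH]c3c2)n1` gives 215000 nM; the one step measured between them, a 3.1-fold lower number from compound 1 to compound 3 (0.49 log units; beyond the scatter), concerns an amino group and not the ether. Compound 2 `Nc1nccc(-c2cc(OCc3ccccc3)c3c(N)n[nH]c3c2)n1` stands lowest of the three at 85000 nM, below compound 3 and furthest from compound 1. Compound 4 `CC(C)Oc1cc(-c2ccnc(N)n2)cc2[nH]nc(N)c12` differs from compound 2 by isopropyl in place of benzyl on an oxygen on an aromatic ring. Among the measured compounds shown here, no measured step touches this change, so the expectation rests only on compound 2 sitting at the bottom of the range. Compound 4 is expected to rise by a 1.8-fold higher number from compound 2 to compound 4 (0.25 log units; within the scatter), a modest step. The estimate for compound 4 is 150000 nM, between 60000 nM and 400000 nM.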

Compound 4, solubility: 354000 nM
Compound 4: the middle estimate sits 2.4-fold (0.37 log units) below what was measured; low and high end bracket the measured number.
By their numbers in this assay, from the lowest: compound 2; then compounds 3, 4 and 1 (each within the scatter of the next, the first and the last beyond it).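

Among these compounds, this is the first measured step at this position: in this assay, isopropyl in place of benzyl on an oxygen on an aromatic ring gives a 4.2-fold higher number from compound 2 to compound 4 (0.62 log units; beyond the scatter), so the group on this oxygen moves the number beyond the scatter. Among the compounds shown here, the only earlier step concerned an amino group and could say nothing about this oxygen. Nothing measured here explains the step. The pair cannot separate the loss of the aromatic ring from the change in heavy atoms, which a cyclohexylmethyl group on the same oxygen could address. As far as these compounds go, how a methyl group, a longer chain or a chain ending in an amine would read there remains open.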